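Acyl group variation on the ring nitrogen of the core

The source may hold more compounds than are shown below. What is called first, only, known or untested is meant among the compounds shown, and "the series" means these compounds.

Measured compounds in a functional assay on MDA-MB-231 cells (Homo sapiens) for cytotoxicity, read by sulforhodamine B assay, with a stated time of 72 h; on this read-out lower numbers stand for stronger inhibition of growth and higher numbers for weaker inhibition of growth:
compound 1 `CC(=O)N1c2ccccc2CCC1C(=O)Nc1cc(C(F)(F)F)cc(C(F)(F)F)c1`: > 70000 nM, a limit of the assay
compound 2 `COc1ccc(NC(=O)C2CCc3ccccc3N2)cc1`: 51400 nM
compound 3 `O=C(Nc1cc(C(F)(F)F)cc(C(F)(F)F)c1)C1CCc2ccccc2N1C(=O)c1ccc(Cl)cc1`: 2000 nM

Compound 3 gives the lowest number of the two numbers shown in this assay; compound 2 is the nearest, with 51400 nM. Compound 1 sits at the limit of > 70000 nM in this assay, at which 1 of the 3 values shown sits, and is not a number.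

The step under consideration goes from compound 3 to compound 4 `CCC(=O)N1c2ccccc2CCC1C(=O)Nc1cc(C(F)(F)F)cc(C(F)(F)F)c1`: ethyl in place of 4-chlorophenyl on a carbonyl carbon. Among the compounds with values here, the only measured step that bears on it is an at least 35-fold lower number from compound 1 to compound 3 (1.54 log units; beyond the scatter), where 4-chlorophenyl in place of methyl on the same carbonyl carbon brought a large drop in the number. Compound 4 carries ethyl at that position, one carbon more than the methyl of compound 1 and without the aromatic ring of compound 3. The expectation is therefore a large rise in the number from compound 3 to compound 4, a 20-fold higher number from compound 3 to compound 4 (1.30 log units; beyond the scatter), most of the way back toward compound 1, with a real chance that only a limit is reported. Compound 4 is estimated at 40000 nM, in the range 10000 nM to 100000 nM.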

Compound 4, concentration for 50% growth inhibition: 7280 nM
Compound 4: the middle estimate sits 5.5-fold (0.74 log units) above what was measured; the whole stated range lies above it.
By their numbers in this assay, from the lowest: compound 3; then compound 4; then compound 2. At a limit, above all of these: compound 1.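

In this assay giving up the aromatic ring at this position costs little: there is a 3.6-fold higher number from compound 3 to compound 4 (0.56 log units; beyond the scatter) for ethyl in place of 4-chlorophenyl, a modest step set against the large one seen with the same aryl group against methyl. Methyl in place of hydrogen on the saturated chain carbon bound to the carbonyl carbon, a far smaller change, already gives an at least 9.6-fold lower number from compound 1 to compound 4 (0.98 log units; beyond the scatter) and so shows that this position responds to the chain alone, with no ring present. Compound 1 stands at a limit and not at a number, so the size of that step is only a bound: the limit of > 70000 nM in this assay, at which 1 of the 4 values shown sits.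

Going by these compounds, whether a longer chain such as butanoyl lowers the number further remains open. So does whether an unsubstituted benzoyl, or an amine on the acyl chain, would hold the number.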